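The compounds below may be only part of what the source reports. "The series", "measured", "known", "first", "only" and "open" are said of these compounds alone.

Measured compounds and their values in this assay:

Compound 1, `O=c1c(SC(=S)N2CCCC2)coc2ccc(Cl)cc12`: > 25000 nM, a limit of the assay.
Compound 2, `O=c1c(SC(=S)N2CCCCC2)coc2ccc(Cl)cc12`: > 25000 nM, a limit of the assay.
Compound 3, `CCOC(=O)c1cc(=O)c2cc(CSC(=S)N3CCCC3)ccc2o1`: > 25000 nM, a limit of the assay.

In a functional assay on SW480 cells (Homo sapiens) for antiproliferative activity, read by MTT assay, with a stated time of 72 h (on this read-out higher numbers stand for weaker inhibition and lower numbers for stronger inhibition), compound 1 gives only a limit, > 25000 nM. Compound 2 also gives only a limit in this assay, > 25000 nM. The change between them, (piperidin-1-yl in place of pyrrolidin-1-yl on a thiocarbonyl carbon), therefore yields a step that the two limits leave unreadable from compound 1 to compound 2, and the reason its size cannot be read is the limit of > 25000 nM in this assay, at which 3 of the 3 values shown sit. Compound 3 likewise gives only a limit in this assay, > 25000 nM. How the core of compound 3 differs from the core of compound 1 is not broken down here.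

Compound 4, `CCOC(=O)c1cc(=O)c2cc(CSC(=S)N3CCCCC3)ccc2o1`, has not yet been measured. It differs from compound 3 by piperidin-1-yl in place of pyrrolidin-1-yl on a thiocarbonyl carbon. The place at which the change is made is described in the same words for both pairs, so this is the same change as that from compound 1 to compound 2, occurring twice among the compounds shown.

For compound 4 the expected step is a step that the limit leaves unreadable from compound 3 to compound 4, beside the earlier one, which could not be read; this expectation rests on compound 3 giving only a limit, > 25000 nM, and on the earlier pair, a step that the two limits leave unreadable from compound 1 to compound 2, showing no readable movement. Compound 4 is thus expected to sit near 40000 nM in this assay, with the estimate spanning 15000 nM to 150000 nM.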

Compound 4, half-maximal inhibitory concentration: > 25000 nM
Compound 4 gave a limit, no number (the forecaster's own chance of this, stated with the estimate: 85%); the middle value lies beyond the limit too.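

In this assay compound 4 gives > 25000 nM, which is a limit of the assay. No step can be read from compound 3 to compound 4, nor from compound 1 to compound 2, since all four compounds share one limit: the limit of > 25000 nM in this assay, at which 4 of the 4 values shown sit. The compounds shown leave open whether piperidin-1-yl and pyrrolidin-1-yl on a thiocarbonyl carbon differ at all in antiproliferative activity on either core.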